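Thienopyridine carboxamides: antiproliferative series, thiourea branch

The source may hold more compounds than are shown below. What is called first, only, known or untested is meant among the compounds shown, and "the series" means these compounds.

Measured to date:
Compound 1, `NC(=O)c1c(NC(=O)c2cccc([N+](=O)[O-])c2)sc2c1CCN(Cc1c(Cl)cccc1Cl)C2`, 18400 nM in a functional assay on HL-60 cells (Homo sapiens) for antiproliferative activity, with a stated time of 24 h; on this read-out higher numbers stand for weaker inhibition and lower numbers for stronger inhibition.
Compound 2, `NC(=O)c1c(NC(=O)c2ccc(C(F)(F)F)cc2)sc2c1CCN(C(=S)Nc1ccccc1Cl)C2`, 36100 nM in this assay.

Compound 2 gives the highest of the two numbers, with compound 1 nearest; the gap between them sits within the scatter, so no order can be read from the pair. Within the data shown here, compound 1 and compound 2 differ in more than one place, and no single step between them is known.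

Compound 3, `NC(=O)c1c(NC(=O)c2cccc([N+](=O)[O-])c2)sc2c1CCN(C(=S)Nc1ccccc1Cl)C2`, has not been measured. Against compound 2 the change is 3-nitrophenyl in place of 4-(trifluoromethyl)phenyl on a carbonyl carbon. Among the measured compounds shown here, the only other compound carrying 3-nitrophenyl is compound 1, and its number does not stand apart from compound 2 beyond the scatter. No step beyond the scatter is therefore expected in this assay for compound 3, which is estimated to move by a 1.4-fold lower number from compound 2 to compound 3 (0.14 log units; within the scatter). Compound 3 is expected to give about 26000 nM in this assay, with a range from 8000 nM to 85000 nM.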

Compound 3, half-maximal inhibitory concentration: 7040 nM
Compound 3: the middle estimate sits 3.7-fold (0.57 log units) above what was measured; measured number outside the range, below it.
By their numbers in this assay, from the lowest: compound 3; then compounds 1 and 2 (each within the scatter of the next).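

On a carbonyl carbon whose other neighbours are an amide-type nitrogen, 3-nitrophenyl in place of 4-(trifluoromethyl)phenyl gives a 5.1-fold lower number from compound 2 to compound 3 (0.71 log units; beyond the scatter) in this assay, so this position does respond to the choice of aryl group, which the first two compounds could not show. With 3-nitrophenyl held fixed, the amine nitrogen in the ring also responds: the group of 10 heavy atoms in place of the group of 9 heavy atoms gives a 2.6-fold lower number from compound 1 to compound 3 (0.42 log units; beyond the scatter) in the same assay. No measurement at hand accounts for either step.

As far as these compounds go, each step rests on a single pair, so whether the carbonyl-side change gives a similar step with the ring-nitrogen group of compound 1 stays open. From the compounds shown here alone, how an amine or a carboxylic acid in place of the nitro group would read also stays open.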